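Prodrug carbonates and esters of the azido nucleoside: cytotoxicity

The compounds below may be only part of what the source reports. "The series", "measured", "known", "first", "only" and "open" are said of these compounds alone.

Measured compounds and values
- compound 1, `Cc1cn(C2CC(N=[N+]=[N-])C(COC(=O)OCCCC(=O)OC(C)(C)C)O2)c(=O)[nH]c1=O`: > 50000 nM
- compound 2, `CCCCOC(=O)OCC1OC(n2cc(C)c(=O)[nH]c2=O)CC1N=[N+]=[N-]`: > 50000 nM
- compound 3, `Cc1cn(C2CC(N=[N+]=[N-])C(COC(=O)CCCC(=O)O)O2)c(=O)[nH]c1=O`: > 50000 nM

All three measured compounds share one core and differ only in the chain attached through the oxygen next to a carbonyl group. In a functional assay on MT4 cells (Homo sapiens) for cytotoxicity (on this read-out lower numbers stand for higher toxicity in this test and higher numbers for lower toxicity in this test), compound 1 reaches only the limit of the assay, > 50000 nM. In this assay compound 2 likewise gives a limit, > 50000 nM. Compound 3 also stops at a limit, > 50000 nM. Because every value shown sits at the limit of > 50000 nM in this assay, at which 3 of the 3 values shown sit, neither a step that the two limits leave unreadable from compound 1 to compound 2 nor a step that the two limits leave unreadable from compound 2 to compound 3 can be read as a number; both are unreadable in size and direction. Compound 3 therefore stands at the limit, alongside the two other values, with no ordering among the three.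

The next compound, compound 4, `Cc1cn(C2CC(N=[N+]=[N-])C(COC(=O)OCCO)O2)c(=O)[nH]c1=O`, is made from compound 3 by the change (2-hydroxyethoxy in place of 3-carboxypropyl on a carbonyl carbon). For the measured compounds named here, no measured step bears on it with a readable size, since every step so far is hidden by the limit. No step beyond the scatter is expected in this assay, so a step that the limit leaves unreadable from compound 3 to compound 4 is estimated as flat. Compound 4 is accordingly expected to give 100000 nM in this assay, with an estimated range from 50000 nM to 300000 nM, most probably reported again only as a limit.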

Compound 4, half-maximal cytotoxic concentration: > 50000 nM
Compound 4: a limit, no number (the forecaster's own chance of this, stated with the estimate: 85%); the middle value is on the limit's open side.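

In this assay compound 4 gives > 50000 nM, which is a limit. The steps from compound 1, compound 2 and compound 3 to compound 4 cannot be read, because every value stops at the same limit: the limit of > 50000 nM in this assay, at which 4 of the 4 values shown sit. The compounds shown leave open whether any chain on the shared core gives a readable number, and how these chains would rank.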